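Replacing ethoxy with nitro on compound 3

The source may report more compounds than this note shows. Statements on the series, on what has been measured and on what is new or still open speak of the compounds shown alone.

Of the compounds shown here, three have been measured in a functional assay on the whole organism for inhibition, with Rattus norvegicus as the target; a lower number here means that less compound is needed, a higher number that more compound is needed for the effect. Compound 1 `CCOC(=O)c1cnc2n(c1=O)C(C)CC/C2=N\Nc1ccccc1C(=O)O` gives 10 umol/kg. Compound 2 `CC1CC/C(=N\Nc2cccc(Cl)c2)c2ncc(C(=O)O)c(=O)n21` gives 0.6 umol/kg. Compound 3 `CCOc1cccc(N/N=C2\CCC(C)n3c2ncc(C(=O)O)c3=O)c1` gives 0.2 umol/kg, the lowest of the three numbers; the nearest is compound 2, and the gap to compound 1 is far wider. Among the measured compounds shown here, the only single-point step among them is a 3.0-fold lower number from compound 2 to compound 3 (0.48 log units; beyond the scatter), a modest step showing that the group on the six-membered aromatic ring of carbon only moves the result by a meaningful but not dramatic amount.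

Compound 4 `CC1CC/C(=N\Nc2cccc([N+](=O)[O-])c2)c2ncc(C(=O)O)c(=O)n21` is the next member of the set. Its difference from compound 3 is nitro in place of ethoxy on an aromatic carbon. For the measured compounds named here, no measured compound carries a nitro group, so no step bears on this change directly; the step from compound 2 to compound 3 is the only guide to the weight of this position, and it suggests a change of similar size in either direction rather than a large one. On that basis compound 4 is expected to come out somewhat above compound 3, with a 2.5-fold higher number from compound 3 to compound 4 (0.40 log units; beyond the scatter) as the estimated step. The estimate for compound 4 is 0.5 umol/kg, ranging from 0.15 umol/kg to 2 umol/kg.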

Compound 4, dose for 50% inhibition: 0.5 umol/kg
For compound 4 middle estimate and measured number coincide at the digits printed; the measured number falls inside the stated range.
By their numbers in this assay, from the lowest: compound 3; then compounds 4 and 2 (each within the scatter of the next); then compound 1.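

In this assay, the place on the six-membered aromatic ring of carbon only, meta to a large group, now carries three different groups on the shared core, which gives a second and a third comparison there: nitro in place of ethoxy gives a 2.5-fold higher number from compound 3 to compound 4 (0.40 log units; beyond the scatter), and nitro in place of chloro gives a 1.2-fold lower number from compound 2 to compound 4 (0.08 log units; within the scatter). Nitro and chloro therefore cannot be told apart at this place, whereas ethoxy stands apart from both, with its steps to each of them beyond the scatter. Ethoxy and nitro have the same count of heavy atoms, so that count alone does not separate the two groups, and the step between them must lie in what differs, the atoms themselves and the hydrogen-bond acceptors counted for each.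

Nothing at hand explains why ethoxy differs from the other two groups. The compounds shown also leave open whether the lower number of compound 3 is particular to ethoxy or extends to a longer chain such as propoxy, and how an amine or a carboxylic acid at this place would compare.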